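A few compounds are considered here, and "the series" means these few. Any claim that something is new, unique, unknown or untested is made for them only; others in the source may bear on it.

Of the compounds shown here, two that share one core have so far been tested in a functional assay on the whole organism for inhibition, with Rattus norvegicus as the target, at a dose of 30 mg/kg; a higher number here means more inhibition at the dose given (going by the name of the read-out), a lower number less inhibition. Compound 1 `Clc1ccc(-c2nc3ncccc3o2)cc1` gives 24% in this assay. Compound 2 `Fc1ccc(-c2nc3ncccc3o2)cc1` gives 28% in this assay. Among the compounds with values here, the only measured step between them, a number 4 percentage points higher from compound 1 to compound 2 (within the scatter), is a fluoro in place of chloro on an aromatic carbon, and it lies within the scatter. Compound 2 therefore carries the higher of the two numbers, but since its gap to compound 1 is within the scatter, the two compounds cannot be told apart on these numbers.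

Compound 3 `COc1ccc(-c2nc3ncccc3o2)cc1` has not yet been measured. It differs from compound 2 in one place: methoxy in place of fluoro on an aromatic carbon. Within the data shown here, no measured step swaps fluoro for methoxy, so the one step that exists bears only loosely on it, as a sign that exchanging the group at this carbon from chloro to fluoro shifted the read-out by no more than the scatter. On that thin footing, compound 3 is expected to give 25% in this assay, with a range from 5% to 45%. The step from compound 2 that this estimate implies is a number 3 percentage points lower from compound 2 to compound 3 (within the scatter), expected to stay within the scatter.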

Compound 3, a percentage reported as inhibition, in the whole organism at one dose (the size of the read-out at that dose, not a potency): 14%
Compound 3: middle estimate off by 11 percentage points, on the high side, within the range that was stated.
By their numbers in this assay, from the lowest: compounds 3, 1 and 2 (each within the scatter of the next, the first and the last beyond it).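

In this assay this carbon, para to a group of 9 heavy atoms, now shows a change of group that stands clear of the scatter: methoxy in place of fluoro gives a number 14 percentage points lower from compound 2 to compound 3 (beyond the scatter) while the earlier exchange of chloro for fluoro left its two compounds indistinguishable. Methoxy in place of chloro gives a number 10 percentage points lower from compound 1 to compound 3 (within the scatter) and so methoxy is set apart from fluoro but not from chloro, which means the three compounds do not form three separate levels and the read-out at this carbon is sensitive to some exchanges only. Nothing at hand explains why methoxy separates from fluoro here.

The compounds shown leave open how an amine, a carboxylic acid or a longer chain such as ethoxy would read at this carbon, and whether anything placed here could raise the number clearly above that of compound 2. They also leave open whether the step from fluoro to methoxy would hold at another carbon of this ring, since every change so far sits at this one place.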